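Hydroxy for ethyl on a triazole side chain: cytotoxicity outlook

The compounds below may be only part of what the source reports. "The series", "measured", "known", "first", "only" and "open" are said of these compounds alone.

Compound 1 `COc1nc2ccc(Br)cc2cc1C(c1ccccc1)n1cc(-c2ccccc2F)nn1` — 13.4%
Compound 2 `CCCc1cn(C(c2ccccc2)c2cc3cc(Br)ccc3nc2OC)nn1` — 8.3%

Compound 2 holds the lower of the two numbers in an ADME assay on PC-3 cells (Homo sapiens) for cytotoxicity, read by sulforhodamine B assay, with a stated time of 48 h, tested at 10 uM (a lower number here means less inhibition, a higher number more inhibition at the concentration tested (going by the name of the read-out)), yet compound 1 sits only a step of a number 5.1 percentage points lower from compound 1 to compound 2 (within the scatter) away, so the two stand together within the scatter. Compound 3 `COc1nc2ccc(Br)cc2cc1C(c1ccccc1)n1cc(CO)nn1` has not yet been measured. Its difference from compound 2 is hydroxy in place of ethyl on a saturated chain carbon bound to an aromatic carbon. Among the measured compounds shown here, the only measured step that bears on this change is the one in which the same triazole substituent was altered, from compound 1 to compound 2, and that exchange of 2-fluorophenyl for propyl moved the read-out by a number 5.1 percentage points lower from compound 1 to compound 2 (within the scatter), within the scatter. For the measured compounds named here, with only that step as a guide, compound 3 is expected to remain near compound 2, with a step of a number 0.7 percentage points higher from compound 2 to compound 3 (within the scatter) that does not go beyond the scatter. Compound 3 is therefore estimated at 9%, within a range of 0% to 22%.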

Compound 3, a percentage reported as inhibition, at one concentration (the size of the read-out at that concentration, not a potency): 4.65%
Compound 3: middle estimate off by 4.4 percentage points, on the high side; measured number inside the range.
By their numbers in this assay, from the lowest: compounds 3, 2 and 1 (each within the scatter of the next).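

At the position on the triazole, hydroxymethyl now stands with propyl and 2-fluorophenyl, and in this assay the exchanges give a number 3.7 percentage points lower from compound 2 to compound 3 (within the scatter) and a number 8.8 percentage points lower from compound 1 to compound 3 (within the scatter). A group with a hydrogen-bond donor and a hydrogen-bond acceptor therefore stays within the scatter of both the propyl and the 2-fluorophenyl compound, which the earlier pair, holding no hydroxy group, could not show. No measurement shown bears on a cause for this result.

All three numbers stand together at the single concentration tested, so the compounds shown do not tell whether any group at this position can take the read-out beyond the scatter. Going by these compounds, what an amine, a carboxylic acid or a longer chain ending in hydroxy would give on the triazole remains open.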